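Amide tail swap on the shared core: nitrile pair to hydroxyethyl

The compounds below may be only part of what the source reports. "The series", "measured", "known", "first", "only" and "open" are said of these compounds alone.

Compound 1 `CCN(CC)CCNC(=O)c1ccc(C(CC)(CC)c2ccc(OCCC(O)(CC)CC)c(C)c2)n1CC` gives 550 nM in a functional assay on MCF7 cells (Homo sapiens) for antiproliferative activity, read by MTT assay, with a stated time of 48 h; a lower number here means a stronger inhibitor, a higher number a weaker inhibitor.
Compound 2 `CCn1c(C(=O)N(CCC#N)CCC#N)ccc1C(CC)(CC)c1ccc(OCCC(O)(CC)CC)c(C)c1` gives only a limit, > 50000 nM, in this assay.
Compound 3 `CCn1c(C(=O)NC(C)C(=O)O)ccc1C(CC)(CC)c1ccc(OCCC(O)(CC)CC)c(C)c1` gives 19700 nM in this assay.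

Compound 2 stands at the limit of this assay (the limit of > 50000 nM in this assay, at which 1 of the 3 values shown sits); no number is known for it. Compound 4 `CCn1c(C(=O)N(C)CCO)ccc1C(CC)(CC)c1ccc(OCCC(O)(CC)CC)c(C)c1` differs from it by a group of 5 heavy atoms (3 carbon, 1 nitrogen, 1 oxygen; no ring) in place of a group of 9 heavy atoms (6 carbon, 3 nitrogen; no ring), on a carbonyl carbon. Among the compounds with values here, two measured steps bear on this. The step of an at least 90-fold higher number from compound 1 to compound 2 (1.95 log units; beyond the scatter) shows the nitrile pair costing a great deal, and the step of an at least 2.5-fold lower number from compound 2 to compound 3 (0.40 log units; beyond the scatter) shows that leaving it recovers some potency. A shorter, donor-bearing tail is therefore expected to bring the number back below the limit, as an at least 6.2-fold lower number from compound 2 to compound 4 (0.79 log units; beyond the scatter). For compound 4 the estimate is 8000 nM, between 2000 nM and 40000 nM.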

Compound 4, half-maximal inhibitory concentration: 2870 nM
Compound 4: middle estimate off by 2.8-fold (0.45 log units), on the high side; low and high end bracket the measured number.
By their numbers in this assay, from the lowest: compound 1; then compound 4; then compound 3. At a limit, above all of these: compound 2.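

Of the tails tried on this carbonyl carbon, (2-hydroxyethyl)(methyl)amino gives an at least 17-fold lower number from compound 2 to compound 4 (1.24 log units; beyond the scatter), and (1-carboxyethyl)amino does worse, with a 6.9-fold lower number from compound 3 to compound 4 (0.84 log units; beyond the scatter). Even so, (2-(diethylamino)ethyl)amino remains ahead, with a 5.2-fold higher number from compound 1 to compound 4 (0.72 log units; beyond the scatter), so this tail recovers much of the potency but not all of it. The first step is only a bound, with compound 2 known by a limit and not a number: the limit of > 50000 nM in this assay, at which 1 of the 4 values shown sits.

Which part of the new tail matters cannot be told from these steps. On these data alone, a (2-hydroxyethyl)amino tail without the methyl, or a longer chain ending in a dimethylamino group, remains open.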